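Trimming a Side Chain on a Shared Purine-Derived Core

The compounds below may be only part of what the source reports. "The series", "measured", "known", "first", "only" and "open" are said of these compounds alone.

Of the compounds shown here, three built on the same core have been tested in a functional assay on the whole organism (Tail, strain ICR) with Mus musculus as the target, in the tail flick test, with a stated time of 90 min, at a dose of 25 umol/kg by the oral route; on this read-out higher numbers stand for a stronger effect at the one dose given and lower numbers for a weaker effect. Compound 2, `O=C(O)CC[C@H](NC(=O)CN(c1nc(Cl)nc2[nH]cnc12)C1CC1)C(=O)O`, gives 44.7% in this assay. Compound 1, `O=C(OCc1ccccc1)[C@@H]1CCCN1C(=O)CN(c1nc(Cl)nc2[nH]cnc12)C1CC1`, gives 43.3%, and compound 3, `NC(=O)C[C@H](NC(=O)CN(c1ncnc2c1ncn2C1CCCCO1)C1CC1)C(=O)OCc1ccccc1`, gives 35%. The figure for compound 2 is the largest of the three shown, but its gaps to compound 1 and to compound 3 both lie within the usual scatter, so the three values cannot be told apart with confidence.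

Compound 4, `O=C(O)CNC(=O)CN(c1nc(Cl)nc2[nH]cnc12)C1CC1`, has not been measured yet. It differs from compound 2 in one place: hydrogen in place of 2-carboxyethyl on a saturated chain carbon bound to an amide-type nitrogen and a carbonyl carbon. A group carrying one hydrogen-bond donor and one acceptor is cut away and nothing heavier than a hydrogen takes its place.

The three measured compounds carry quite different side groups on the amide part yet land close together, which suggests that this part of the molecule does not move the read-out much. For compound 4 the expected step of a number 4.7 percentage points lower from compound 2 to compound 4 (within the scatter) is therefore small, likely no larger than the scatter, if anything a slight drop. The estimate for compound 4 is 40%, with a range from 25% to 55%.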

Compound 4, a percentage reported as activity, at one dose (the size of the read-out at that dose, not a potency): 32.3%
Compound 4: middle estimate off by 7.7 percentage points, on the high side, within the range that was stated.
By their numbers in this assay, from the lowest: compounds 4, 3, 1 and 2 (each within the scatter of the next, the first and the last beyond it).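

In this assay, cutting the 2-carboxyethyl group back to hydrogen gives a number 12.4 percentage points lower from compound 2 to compound 4 (beyond the scatter), so what sits on this saturated chain carbon bound to an amide-type nitrogen and a carbonyl carbon does affect the read-out. Among these compounds, the earlier compounds could not show this: they differ from one another in more than one place, whereas this is the first pair that differs in only one. Nothing measured here accounts for the drop.

Going by these compounds, with only hydrogen and 2-carboxyethyl at this place, it remains open whether the carboxylic acid at the end of the chain matters or the carbon chain alone is enough; a methyl group, or a propyl chain with no acid, would help separate the two. On these data alone, the read-out also comes from a single dose, so whether the step holds at other doses is unknown.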